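A few compounds are considered here, and "the series" means these few. Any claim that something is new, unique, unknown or untested is made for them only; others in the source may bear on it.

Of the compounds shown here, three have been measured in a functional assay on cells for antagonist activity at Oxytocin receptor (Homo sapiens), read by a beta-lactamase reporter; a higher number here means a weaker inhibitor, a lower number a stronger inhibitor. Compound 3 `COc1ccc2oc(C(=O)N(C)c3ccc(OC)nc3)cc2c1` gives 232 nM. Compound 2 `COc1ccc(N(C)C(=O)c2cnc(-c3ccc(F)cc3C)cn2)cn1` gives 218 nM, and compound 1 `CCN(C(=O)c1cnc(-c2ccccc2C)cn1)c1ccc(OC)nc1` gives 129 nM. All three numbers lie within the usual scatter of one another, so on the numbers shown nothing separates compound 3 from the other two. Compound 4 `CCN(C(=O)c1cc2cc(OC)ccc2o1)c1ccc(OC)nc1` is not yet measured. It differs from compound 3 by methyl in place of hydrogen on a saturated chain carbon bound to an amide-type nitrogen. Going by the values given here, no measured pair differs in this one place alone, so the data offer no step of this kind to lean on, and compound 1 and compound 2 differ from each other in more than one place. A step from compound 3 to compound 4 of a 1.3-fold lower number from compound 3 to compound 4 (0.11 log units; within the scatter) is expected, not beyond the scatter. Compound 4 is estimated at 180 nM in this assay, within a range from 80 nM to 400 nM.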

Compound 4, inhibition constant: 85 nM
The estimate for compound 4 lay 2.1-fold (0.33 log units) above the measured number; measured number inside the range.
By their numbers in this assay, from the lowest: compounds 4, 1, 2 and 3 (each within the scatter of the next, the first and the last beyond it).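

In this assay, the change from methyl to ethyl on the amide-type nitrogen gives a 2.7-fold lower number from compound 3 to compound 4 (0.44 log units; beyond the scatter), so this position does respond to a single added methyl. Going by these compounds alone, this is the only step read so far, and it rests on one pair on one core. Nothing measured here offers an explanation for the step. Going by these compounds, whether the same change carries over to other cores stays open. So does the outcome at this position of a longer chain such as propyl, or of a chain ending in an amine.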